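This account rests on a few compounds, and the source may have more. Where it says the series, first, only, none or still open, it means among the compounds named here.

Within the data shown here, compound 2 `CCCCCCCOc1ccc(CC[C@](C)(N)CC(=O)O)cc1` is the only compound of this set that comes with a number. In a functional assay on CHO cells for agonist activity at sphingosine 1-phosphate receptor 5 (Homo sapiens), read by GTPgammaS binding (a lower number here means that less compound is needed, a higher number that more compound is needed for the effect), compound 2 gives 200 nM. Among the measured compounds shown here, compound 1 `CCCCCCCOc1ccc(CC[C@](C)(N)CCS(=O)(=O)O)cc1` has no number in this assay: for compound 1 the result is "not determined" (no result reported), so there is no pair of measured compounds from which the size of any structural step could be read. Compound 3 `CCCCCCCOc1ccc(CC[C@](C)(N)CCc2nnn[nH]2)cc1` has not yet been measured. It differs from compound 2 in one place: (1H-tetrazol-5-yl)methyl in place of carboxy on a saturated chain carbon, two bonds along the chain from an amine nitrogen. For the measured compounds named here, with no measured pair showing what such a replacement does in this assay, the expectation can rest only on the single value of compound 2. The expected step is a 2.3-fold higher number from compound 2 to compound 3 (0.35 log units; beyond the scatter). Compound 3 is accordingly estimated at 450 nM, with a range from 100 nM to 2500 nM.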

Compound 3, half-maximal effective concentration: 3600 nM
Beside the measured number, compound 3's estimate is 8.0-fold (0.90 log units) below it, and the stated range ends below it.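

Among these compounds, this is the first size read for any change at this position. In this assay, (1H-tetrazol-5-yl)methyl in place of carboxy on a saturated chain carbon, two bonds along the chain from an amine nitrogen, gives an 18-fold higher number from compound 2 to compound 3 (1.26 log units; beyond the scatter), so the replacement is far from neutral here and carboxy is the better of these two groups. Nothing given here accounts for the size of this step.

The entering group brings both the ring and a longer link to it, so the compounds shown do not separate these two parts; a 1H-tetrazol-5-yl group set directly in place of carboxy, or a longer chain ending in a carboxylic acid, would bear on that. Steps to or from compound 1 cannot be read, so how its sulfonic acid ranks against carboxy and the tetrazole stays open.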